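Swapping Methyl for Chloro on a Quaternary Ammonium Quinolone Series

The source may hold more compounds than are shown below. What is called first, only, known or untested is meant among the compounds shown, and "the series" means these compounds.

Four compounds share one core and differ in the ring that carries the long chain with its charged nitrogen, and in the group on that chain's end. Compound 1 `CC[N+]1(CCCCCCCOc2ccc(-n3cc(C(=O)Nc4cc(F)cc(F)c4)c(=O)c4ccc(N(C)C)nc43)cc2C)CCCCC1` and compound 2 `CC[N+]1(CCCCCCCOc2ccc(-n3cc(C(=O)Nc4cc(F)cc(F)c4)c(=O)c4ccc(N(C)C)nc43)cc2Cl)CCCCC1` carry a seven-carbon chain ending in a charged ethyl-piperidinium. In an assay on LX2 cells for inhibition of COL1A1 promoter (Homo sapiens), read by a luciferase reporter, with a stated time of 24 h, tested at 50 uM (a higher number here means a stronger effect of the compound at the concentration tested, a lower number a weaker effect), compound 1 gives 53.4%, and compound 2 gives 50.4%. The step of a number 3 percentage points lower from compound 1 to compound 2 (within the scatter) is the change (chloro in place of methyl on an aromatic carbon), and it leaves the read-out essentially where it was.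

Compound 3 `Cc1cc(OCCCCCCC[N+]2(C)CCN(C)CC2)ccc1-n1cc(C(=O)Nc2cc(F)cc(F)c2)c(=O)c2ccc(N(C)C)nc21` instead ends its chain in a charged dimethyl-piperazinium, and the difference between the core of compound 3 and the core of compound 1 is not broken down here. In this assay compound 3 was reported as "not active" (no number reported), with no number given.

Compound 4 `CN1CC[N+](C)(CCCCCCCOc2ccc(-n3cc(C(=O)Nc4cc(F)cc(F)c4)c(=O)c4ccc(N(C)C)nc43)c(Cl)c2)CC1` is compound 3 with the change (chloro in place of methyl on an aromatic carbon). Within the data shown here, this is the same kind of change as the one from compound 1 to compound 2; its place line reads the same word for word. Because the step of a number 3 percentage points lower from compound 1 to compound 2 (within the scatter) lies within the scatter, the same change on compound 3 is expected to move the read-out little, so compound 4 is expected to stay near the inactive level of compound 3. The estimate for compound 4 in this assay is 10%, expected to fall between 0% and 30%.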

Compound 4, a percentage reported as inhibition, at one concentration (the size of the read-out at that concentration, not a potency): "not active" (no number reported)
Compound 4 has no reported number here; there is nothing to compare the estimate with.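

In this assay compound 3 reads "not active" (no number reported) and compound 4 reads "not active" (no number reported) so no new step can be read between compound 3 and compound 4. No measured evidence bears on this result. The compounds shown leave open whether chloro in place of methyl changes the read-out at all in compounds whose chain ends in the charged dimethyl-piperazinium.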